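Ring nitrogen methylation in the bridged alpha4/beta2 agonist series

The compounds below may be only part of what the source reports. "The series", "measured", "known", "first", "only" and "open" are said of these compounds alone.

Of the compounds shown here, two have been measured in an in vitro functional assay on SH-EP1 cells for agonist activity at Neuronal acetylcholine receptor; alpha4/beta2 (Homo sapiens), read by voltage clamp; on this read-out higher numbers stand for larger maximal responses and lower numbers for smaller maximal responses. Compound 1 `CN1C[C@H]2C=C(c3cccnc3)C[C@H](C2)C1` gives 19% in this assay. Compound 2 `CC(C)Oc1cncc(C2=CC3CNCC(C2)C3)c1` gives 11% in this assay. Among the measured compounds shown here, only these two numbers exist; the gap between compound 2 and compound 1 lies within the usual scatter, so neither can be set apart from the other on this read-out, and the two differ in more than one place, so no single step between them can be read.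

Compound 3 `CC(C)Oc1cncc(C2=CC3CC(C2)CN(C)C3)c1` has not yet been measured in this assay. Relative to compound 2 the change is methyl in place of hydrogen on an amine nitrogen in a ring. Compound 1 already carries a methyl on its ring nitrogen and sits within the scatter of compound 2, which offers no sign that this change moves the maximal response by much. The step from compound 2 to compound 3 is therefore expected to be small, with no direction beyond the scatter, as a number 4 percentage points higher from compound 2 to compound 3 (within the scatter). For compound 3 the estimate in this assay is 15%, in the range from 5% to 32%.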

Compound 3, largest response reached (reported as percent of maximum), in percent of the reference or control that the assay uses: 10%
The estimate for compound 3 lay 5 percentage points above the measured number; low and high end bracket the measured number.
By their numbers in this assay, from the lowest: compounds 3, 2 and 1 (each within the scatter of the next).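

In this assay, among the compounds shown here, methyl in place of hydrogen on an amine nitrogen in a ring gives a number 1 percentage points lower from compound 2 to compound 3 (within the scatter) and so supplies the first single step that can be read, where the earlier pair differed in more than one place. The comparison now isolates the nitrogen of the six-membered non-aromatic ring with 1 nitrogen: on the shared core of compound 2 and compound 3, hydrogen and methyl at this position cannot be told apart on the maximal response. No measurement on hand accounts for this result or links it to any property of the methyl group.

This single step does not show whether a larger group on the same nitrogen, such as ethyl, a longer chain or benzyl, would leave the maximal response equally undisturbed, or whether an acetyl group, which replaces the amine with an amide, would do so. It also leaves open whether methyl in place of hydrogen would give a similar step when the group on the aromatic ring of the shared core is changed, for instance to a methoxy group or an amine.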